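Trimming an Amide Substituent on a Growth-Inhibiting Scaffold

The compounds below may be only part of what the source reports. "The series", "measured", "known", "first", "only" and "open" are said of these compounds alone.

Of the compounds shown here, three built on a shared core have been tested in a functional assay on NCI-H1975 cells (Homo sapiens) for antiproliferative activity, read by CCK-8 assay, with a stated time of 72 h; a lower number here means a stronger inhibitor of growth, a higher number a weaker inhibitor of growth. Compound 1 `CC[C@@H]1C(=O)N(C)c2cnc(Nc3ccc(S(=O)(=O)NCCO)cc3)nc2N1C1CCCC1` gives 2100 nM in this assay. Compound 2 `CCCCNS(=O)(=O)c1ccc(Nc2ncc3c(n2)N(c2ccn(C)n2)C(CC)C(=O)N3C)cc1` gives 4120 nM in this assay. Compound 3 `CC[C@@H]1C(=O)N(C)c2cnc(-n3ccc4cc(C(=O)NC5CCCC5)ccc43)nc2N1C1CCCC1` gives 856 nM in this assay; this is the lowest of the three numbers, and its gaps to compound 1 and to compound 2 both lie beyond the usual scatter, so compound 3 is the strongest growth inhibitor measured so far.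

Compound 4 `CCNC(=O)c1ccc2c(ccn2-c2ncc3c(n2)N(C2CCCC2)[C@H](CC)C(=O)N3C)c1` has not yet been measured. It differs from compound 3 by ethyl in place of cyclopentyl on an amide-type nitrogen, so the cyclopentylcarbamoyl group becomes an ethylcarbamoyl group. Within the data shown here, no measured pair shows this kind of change, so its effect cannot be read from the measured numbers. The step is expected to be modest and toward a higher number, quite possibly within the scatter, as a 1.8-fold higher number from compound 3 to compound 4 (0.24 log units; within the scatter). Compound 4 is therefore estimated to give about 1500 nM in this assay, within a range from 500 nM to 4500 nM.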

Compound 4, concentration for 50% growth inhibition: 882 nM
Compound 4: the middle estimate sits 1.7-fold (0.23 log units) above what was measured; low and high end bracket the measured number.
By their numbers in this assay, from the lowest: compounds 3 and 4 (each within the scatter of the next); then compounds 1 and 2 (each within the scatter of the next).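

Putting ethyl in place of cyclopentyl on the amide-type nitrogen removes the ring and takes this group from 5 heavy atoms to 2, yet this assay gives a 1.0-fold higher number from compound 3 to compound 4 (0.01 log units; within the scatter), so the two compounds cannot be told apart. For this one pair, then, the cyclopentyl ring is not needed to keep the growth-inhibiting effect seen with compound 3, and the ethylcarbamoyl group serves as well as the cyclopentylcarbamoyl group. No measurement available here accounts for this result.

The compounds shown leave open whether a methyl, a longer chain, or a chain ending in an amine or a carboxylic acid on this nitrogen would give a similar number. They also leave open whether ethyl and cyclopentyl would match again with other groups elsewhere on the shared core.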